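Shortening the Alkyl Chain: From Compound 2 to Compound 4

The compounds below may be only part of what the source reports. "The series", "measured", "known", "first", "only" and "open" are said of these compounds alone.

Compound 1 `CCCCCCCCc1cn([C@H]2C[C@H](O)[C@@H](CO)O2)c(=O)[nH]c1=O`: 66 ug/mL
Compound 2 `CCCCCCc1cn([C@H]2C[C@@H]3OP(=O)(O)OC[C@H]3O2)c(=O)[nH]c1=O`: > 500 ug/mL
Compound 3 `CCCc1cn([C@H]2C[C@H](O)[C@@H](CO)O2)c(=O)[nH]c1=O`: > 500 ug/mL

In a functional assay on L1210 cells (Mus musculus) (a lower number here means a stronger inhibitor, a higher number a weaker inhibitor), compound 1 gives 66 ug/mL. For compound 2 the assay reports only a limit, > 500 ug/mL, and not a number. For compound 3 likewise only a limit is reported, > 500 ug/mL. Compound 2 therefore stands at the limit of > 500 ug/mL in this assay, at which 2 of the 3 values shown sit, so its inhibition is known only to be weak.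

Compound 4 `CCCCc1cn([C@H]2C[C@@H]3OP(=O)(O)OC[C@H]3O2)c(=O)[nH]c1=O` differs from compound 2 in a single place: hydrogen in place of ethyl on a saturated chain carbon, four bonds along the chain from an aromatic carbon. One measured step speaks to such a shortening of the chain: an at least 7.5-fold higher number from compound 1 to compound 3 (0.87 log units; beyond the scatter). That step removed more carbons than the present one, but it ran in the same direction, toward weaker inhibition, and beyond the scatter. Since compound 2 already sits at the limit, a further shortening is expected to leave compound 4 at or beyond that limit, with no number reported. Compound 4 is therefore estimated at 1000 ug/mL, within a range of 500 ug/mL to 5000 ug/mL. The step that the limit leaves unreadable from compound 2 to compound 4 is expected to be one of no gain, most likely a result that is again only a limit.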

Compound 4, concentration for 50% inhibition: 28.4 ug/mL
Compound 4: the middle estimate sits 35-fold (1.55 log units) above what was measured, outside the stated range (below it).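

Removing ethyl at this place, four bonds along the chain from an aromatic carbon, brings a clear gain rather than a loss: the result is an at least 17-fold lower number from compound 2 to compound 4 (1.24 log units; beyond the scatter). Shortening the chain therefore has no single direction among the compounds shown, since on a different core it went the other way, with an at least 7.5-fold higher number from compound 1 to compound 3 (0.87 log units; beyond the scatter). The true size of the new step stays unknown because it starts from a limit of the assay for compound 2 and not from a number: the limit of > 500 ug/mL in this assay, at which 2 of the 4 values shown sit.

The compounds shown leave open how the number moves for other chains on the core of compound 4, such as a shorter ethyl chain or a longer decyl chain, and so whether butyl lies near a best length or is only one point on a longer trend. They also leave open whether a chain ending in an amine or a carboxylic acid would keep the inhibition seen for compound 4, at 28.4 ug/mL.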